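Amino to Nitro: One Change on Compound 1

This account rests on a few compounds, and the source may have more. Where it says the series, first, only, none or still open, it means among the compounds named here.

Compound 1 `COc1ccc(CS(=O)(=O)/C=C/c2ccc(OC)c(OC)c2OC)cc1N`: 5310 nM
Compound 2 `COc1cc(OC)c(NC(=O)CS(=O)(=O)Cc2ccc(OC)c([N+](=O)[O-])c2)c(OC)c1`: 18800 nM
Compound 3 `COc1cc(OC)c(/C=C/S(=O)(=O)Cc2ccc(OC)c(NC(C)=O)c2)c(OC)c1`: 150 nM

All three compounds were tested in a functional assay on HCT-116 cells (Homo sapiens) for cytotoxicity, read by MTT assay, with a stated time of 72 h; a lower number here means a stronger inhibitor of growth, a higher number a weaker inhibitor of growth. On these numbers compound 1 holds the second highest value of the three. Its nearest neighbour is compound 2, whose number is higher, and its furthest is compound 3, whose number is far lower; both gaps lie beyond the usual scatter of the measurement.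

Compound 4 `COc1ccc(CS(=O)(=O)/C=C/c2ccc(OC)c(OC)c2OC)cc1[N+](=O)[O-]` is not yet measured. It differs from compound 1 in one place: nitro in place of amino on an aromatic carbon. Within the data shown here, no measured pair differs only in this way, so there is no directly measured step to lean on. Compound 2 also carries a nitro group, but it differs from compound 1 in several other parts as well, so its value only shows that a nitro-bearing compound can sit at the weak end of this small set.

The expected step of a 1.5-fold higher number from compound 1 to compound 4 (0.18 log units; within the scatter) is small, toward a higher number, and may not exceed the scatter. Compound 4 is estimated at 8000 nM, within a range from 2500 nM to 25000 nM.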

Compound 4, concentration for 50% growth inhibition: 27900 nM
Compound 4: the middle estimate sits 3.5-fold (0.54 log units) below what was measured, outside the stated range (above it).
By their numbers in this assay, from the lowest: compound 3; then compound 1; then compounds 2 and 4 (each within the scatter of the next).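

Putting nitro in place of amino on this aromatic carbon, ortho to a methoxy group, gives a 5.3-fold higher number from compound 1 to compound 4 (0.72 log units; beyond the scatter) in this assay. Among these compounds, this is the first direct reading at this position, and it shows that this single change, with the rest of the molecule held the same, is enough to weaken growth inhibition beyond the scatter. Nothing available here explains the rise.

The compounds shown leave open how a hydroxyl group, a methyl group or a plain hydrogen would behave at this position, so it cannot yet be said whether amino helps, nitro harms, or both. Compound 3 carries an acetylated amino group at this place, but it also differs from compound 1 elsewhere, so its value cannot isolate that group's contribution.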